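Cyclohexylamino for piperidin-1-yl

A few compounds are considered here, and "the series" means these few. Any claim that something is new, unique, unknown or untested is made for them only; others in the source may bear on it.

Measured in an ADME assay on a cell-free system (plasma, Mus musculus) for metabolic stability, tested at 5 uM; a lower number here means that the compound disappears faster, a higher number that the compound lasts longer:
Compound 1 `O=C(O)c1ccc(NCCCCCCCC(F)(F)F)c(S(=O)(=O)N2CCCCC2)c1`: > 2 h
Compound 2 `O=C(O)c1ccc(NCCCCCCCC(F)(F)F)c(S(=O)(=O)N2CCOCC2)c1`: > 2 h

Compound 1 stands at a limit of this assay (> 2 h), not at a true number. Compound 2 also gives only a limit (> 2 h). So the whole data set sits at one limit (the limit of > 2 h in this assay, at which 2 of the 2 values shown sit).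

Compound 3 `O=C(O)c1ccc(NCCCCCCCC(F)(F)F)c(S(=O)(=O)NC2CCCCC2)c1` has cyclohexylamino in place of piperidin-1-yl on a sulfonyl sulfur. Among the compounds with values here, the only measured step, a step that the two limits leave unreadable from compound 1 to compound 2, changes that same place, and it shows no readable size. No step beyond the scatter is therefore expected in this assay. The expected change is a step that the limit leaves unreadable from compound 1 to compound 3 (an estimate only). Compound 3 is estimated at 3 h (range 1.5 h to 6 h).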

Compound 3, half-life: > 2 h
Compound 3: no number, only a limit (the forecaster's own chance of this, stated with the estimate: 75%); the middle value lies beyond the limit too.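

Compound 3 gives only a limit of > 2 h in this assay. Its steps from compound 1 and compound 2 therefore cannot be read: the limit of > 2 h in this assay, at which 3 of the 3 values shown sit. As far as these compounds go, what stays open is how long compound 1, compound 2 and compound 3 really last in this assay, and whether the groups on the sulfonyl sulfur make any difference there.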